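The source may report more compounds than this note shows. Statements on the series, on what has been measured and on what is new or still open speak of the compounds shown alone.

Within the data shown here, in a functional assay on HUVEC cells (Homo sapiens), read by scintillation counting and thymidine incorporation, with a stated time of 24 h (on this read-out higher numbers stand for weaker inhibition and lower numbers for stronger inhibition), three compounds on a shared core have numbers so far. Compound 1 `CCC(C)n1ncn(-c2ccc(N3CCN(c4ccc(OC[C@@H]5CO[C@@](CC)(c6ccc(Cl)cc6Cl)O5)cc4)CC3)cc2)c1=O` gives 353 nM, compound 2 `CCC(C)n1ncn(-c2ccc(N3CCN(c4ccc(OC[C@@H]5CO[C@@](Cn6cnc(C)c6)(c6ccc(Cl)cc6Cl)O5)cc4)CC3)cc2)c1=O` gives 102 nM, and compound 3 `CCC(C)n1ncn(-c2ccc(N3CCN(c4ccc(OC[C@@H]5CO[C@@](Cn6cc(C)nc6C)(c6ccc(Cl)cc6Cl)O5)cc4)CC3)cc2)c1=O` gives 492 nM. Compound 3 cannot be told apart from compound 1, as a 1.4-fold higher number from compound 1 to compound 3 (0.14 log units; within the scatter) shows, but it clearly separates from compound 2.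

Compound 4 `CCC(C)n1ncn(-c2ccc(N3CCN(c4ccc(OC[C@@H]5CO[C@@](Cn6ncnn6)(c6ccc(Cl)cc6Cl)O5)cc4)CC3)cc2)c1=O` departs from compound 3 at one place: 2H-tetrazol-2-yl in place of 2,4-dimethyl-1H-imidazol-1-yl on a saturated chain carbon bound to a saturated ring carbon. This puts 2H-tetrazol-2-yl in place of 2,4-dimethyl-1H-imidazol-1-yl on a saturated chain carbon bound to a saturated ring carbon.

No tetrazole has been measured, so the guidance is indirect. The closest evidence is a 4.8-fold higher number from compound 2 to compound 3 (0.68 log units; beyond the scatter), where compound 3 gained a methyl on an aromatic carbon. The other relevant step, a 3.5-fold lower number from compound 1 to compound 2 (0.54 log units; beyond the scatter), is of similar size and shows that compound 2 also holds the lower number. Compound 4 carries no methyl on its ring, so a modest move toward lower numbers is expected, though the range must stay wide. The expected change is a 2.2-fold lower number from compound 3 to compound 4 (0.35 log units; beyond the scatter). The estimate for compound 4 is 220 nM, within a range of 80 nM to 600 nM.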

Compound 4, half-maximal inhibitory concentration: 124 nM
Compound 4: the middle estimate sits 1.8-fold (0.25 log units) above what was measured, and the stated range covers the measured number.
By their numbers in this assay, from the lowest: compounds 2 and 4 (each within the scatter of the next); then compounds 1 and 3 (each within the scatter of the next).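

In this assay, the place on a saturated chain carbon bound to a saturated ring carbon accepts a ring with four nitrogens and no methyl, as a 4.0-fold lower number from compound 3 to compound 4 (0.60 log units; beyond the scatter) and a 2.8-fold lower number from compound 1 to compound 4 (0.45 log units; beyond the scatter) show. Among these compounds, with a 1.2-fold higher number from compound 2 to compound 4 (0.08 log units; within the scatter), the 2H-tetrazol-2-yl group cannot be told apart from the 4-methyl-1H-imidazol-1-yl group, so the step away from compound 1 is now seen with two different rings, and compound 3 is the one ring-bearing compound that goes against it. Nothing measured here explains this result.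

Going by these compounds, it remains open whether a ring is needed at this place at all, which an open-chain amine or a carboxylic acid on the same carbon would test. On these data alone, it is also open whether a methyl on the 2H-tetrazol-2-yl ring would have an effect like that in a 4.8-fold higher number from compound 2 to compound 3 (0.68 log units; beyond the scatter).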